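This account rests on a few compounds, and the source may have more. Where it says the series, first, only, none or still open, it means among the compounds named here.

Measured compounds and their values:

- compound 1 `COc1ncc(NC(=O)[C@H](C)[C@H]2CC[C@@H](c3ccnc4ccc(F)cc43)CC2)cn1`: 10 nM
- compound 2 `C[C@@H](c1nc2ccc(Cl)cc2[nH]1)[C@H]1CC[C@@H](c2ccnc3ccc(F)cc32)CC1`: 4 nM
- compound 3 `C[C@@H](NS(=O)(=O)c1ccc(Cl)cc1)[C@H]1CC[C@@H](c2ccnc3ccc(F)cc32)CC1`: > 1000 nM

All three share the same core and are tested in an assay on tissue (HeLa cells) for inhibition of Indoleamine 2,3-dioxygenase 1 (Homo sapiens), with stated times of 2 h and 18 h; on this read-out lower numbers stand for stronger inhibition and higher numbers for weaker inhibition. Compound 1 gives 10 nM and compound 2 gives 4 nM; these two values sit within the usual scatter of each other. Compound 3 stands apart: its value of > 1000 nM is a limit of this assay, not a number, so only the weakest end of the series is known for it (the limit of > 1000 nM in this assay, at which 1 of the 3 values shown sits).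

Compound 4 `C[C@@H](NC(=O)c1cccc(Cl)c1)[C@H]1CC[C@@H](c2ccnc3ccc(F)cc32)CC1` differs from compound 3 in one place: (3-chlorophenyl)carbonyl in place of (4-chlorophenyl)sulfonyl on an amine nitrogen. Among the measured compounds shown here, no step between two measured compounds with a numbered value is recorded, so the size of this change can only be expected, not read off. Given that compound 1 gives 10 nM and compound 2 gives 4 nM on the same core, the expectation is that compound 4 returns to the range of numbered values. The step from compound 3 to compound 4 is expected to be large, toward stronger inhibition: an at least 33-fold lower number from compound 3 to compound 4 (1.52 log units; beyond the scatter). Compound 4 is estimated at 30 nM, with a likely range from 5 nM to 300 nM.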

Compound 4, half-maximal inhibitory concentration: 7 nM
For compound 4 the middle estimate is 4.3-fold (0.63 log units) above the measured one; the measured number falls inside the stated range.
By their numbers in this assay, from the lowest: compounds 2, 4 and 1 (each within the scatter of the next, the first and the last beyond it). At a limit, above all of these: compound 3.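

In this assay, compound 3, with (4-chlorophenyl)sulfonyl on the amine nitrogen, reads > 1000 nM, which is a limit of the assay and not a number. Placing (3-chlorophenyl)carbonyl on that nitrogen gives an at least 140-fold lower number from compound 3 to compound 4 (2.15 log units; beyond the scatter), so a chlorophenyl group at this position is compatible with strong inhibition, and the result for compound 3 does not rule out the position as a whole. The true size of this step stays unknown, and the printed figure is only a minimum: the limit of > 1000 nM in this assay, at which 1 of the 4 values shown sits.

The change alters two things at once, sulfonyl to carbonyl and 4-chlorophenyl to 3-chlorophenyl, so the compounds shown cannot say which of the two accounts for the step. A (4-chlorophenyl)carbonyl or a (3-chlorophenyl)sulfonyl group on the same nitrogen would separate the two.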